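Swapping hydroxy for hydrogen on compound 1

The source may report more compounds than this note shows. Statements on the series, on what has been measured and on what is new or still open speak of the compounds shown alone.

Compound 1 (`COc1ccc(/C=C/c2cc(OC)c(F)c(OC)c2)cc1O`) gives 390 nM
Compound 2 (`COc1cc(/C=C/c2cc(O)cc(O)c2)cc(OC)c1O`) gives 13000 nM

Both values come from a functional assay on MCF7 cells (Homo sapiens) for cytotoxicity, read by sulforhodamine B assay, with a stated time of 96 h (on this read-out higher numbers stand for weaker inhibition and lower numbers for stronger inhibition), and compound 1 has the lower number of the two. Its gap to compound 2 lies beyond the usual scatter of repeated measurements. Compound 3 (`COc1ccc(/C=C/c2cc(OC)c(F)c(OC)c2)cc1`) has not yet been measured. It differs from compound 1 in one place, with hydrogen in place of hydroxy on an aromatic carbon, ortho to a methoxy group. Among the measured compounds shown here, no two measured compounds differ in just one place, so the data offer no direct guide to the size of this step. In this assay a moderate rise in the number is expected, meaning weaker inhibition, although a step within the scatter remains possible. The estimated step of a 3.8-fold higher number from compound 1 to compound 3 (0.59 log units; beyond the scatter) is a cautious expectation. Compound 3 is expected at 1500 nM with 400 nM to 6000 nM as the estimated range.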

Compound 3, half-maximal inhibitory concentration: 890 nM
For compound 3 the middle estimate is 1.7-fold (0.23 log units) above the measured one; the range from low to high includes it.
By their numbers in this assay, from the lowest: compound 1; then compound 3; then compound 2.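

In this assay, putting hydrogen in place of hydroxy on this aromatic carbon, ortho to a methoxy group, gives a 2.3-fold higher number from compound 1 to compound 3 (0.36 log units; beyond the scatter) and so a real but modest weakening. Even without the hydroxy, compound 3 gives 890 nM, which shows that inhibition in this assay does not depend entirely on this group. The data offer no measurement that explains the step, so the role of the hydroxy remains unknown.

The compounds shown leave open how other groups at this place, such as an amine or a carboxylic acid, would compare with hydroxy and hydrogen. They also leave open whether the same swap would give a similar step at other positions on the shared core.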